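Swapping the Chain End for a Methoxyphenyl Ring

A few compounds are considered here, and "the series" means these few. Any claim that something is new, unique, unknown or untested is made for them only; others in the source may bear on it.

Compound 1 `COc1cc(N)c(Cl)cc1NC(=O)C1CCN(Cc2ccc(F)cc2)CC1` gives 0.6 mg/kg in a functional assay on the whole organism for antagonist activity, with Mus musculus as the target; a lower number here means that less compound is needed, a higher number that more compound is needed for the effect. Compound 2 `COc1cc(N)c(Cl)cc1NC(=O)C1CCN(CC2CCCCCC2)CC1` reaches only the limit > 10 mg/kg in this assay. Compound 3 `COc1cc(N)c(Cl)cc1NC(=O)C1CCN(C/C=C/c2ccccc2)CC1` likewise gives only the limit > 10 mg/kg in this assay.

Compound 3 thus stands at the top edge of what this assay reports; (the limit of > 10 mg/kg in this assay, at which 2 of the 3 values shown sit). Compound 4 `COc1cccc(CN2CCC(C(=O)Nc3cc(Cl)c(N)cc3OC)CC2)c1` differs from it in one place: 3-methoxyphenyl in place of 2-phenylethenyl on a saturated chain carbon bound to an amine nitrogen in a ring. Going by the values given here, two measured steps bear on this. Moving from an aromatic ring to the 2-phenylethenyl group gave an at least 16-fold higher number from compound 1 to compound 3 (1.22 log units; beyond the scatter), and moving to cycloheptyl gave an at least 16-fold higher number from compound 1 to compound 2 (1.22 log units; beyond the scatter), while a step that the two limits leave unreadable from compound 2 to compound 3. Compound 4 puts an aromatic ring back at this place, as in compound 1, whose value of 0.6 mg/kg is the closest guide. A large step toward a lower number is therefore expected, an at least 6.6-fold lower number from compound 3 to compound 4 (0.82 log units; beyond the scatter). Compound 4 is estimated at 1.5 mg/kg, with a likely range from 0.5 mg/kg to 6 mg/kg.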

Compound 4, dose for half-maximal effect: > 4 mg/kg
Compound 4 ended at the assay's limit (the forecaster's own chance of this, stated with the estimate: 20%); middle value at least 2.6-fold (0.42 log units) away from the limit.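

Having an aromatic ring on this saturated chain carbon is not enough on its own to match compound 1: 3-methoxyphenyl in place of 4-fluorophenyl gives an at least 6.6-fold higher number from compound 1 to compound 4 (0.82 log units; beyond the scatter). In this assay compound 4 gives only a limit, not a number: the limit of > 4 mg/kg in this assay, at which 1 of the 4 values shown sits. The steps from compound 2 and from compound 3 to compound 4 cannot be read, since each joins two limits.

The change from 4-fluorophenyl to 3-methoxyphenyl alters both the group on the ring and where it sits, and the compounds shown do not separate these two changes. From the compounds shown here alone, how a plain phenyl ring, carrying neither fluoro nor methoxy, would read at this place also remains open.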